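A few compounds are considered here, and "the series" means these few. Any claim that something is new, unique, unknown or untested is made for them only; others in the source may bear on it.

Measured so far:
compound 1 `COc1ccc([C@@H]2C/C(=N/OCc3cn(-c4ccccc4CO)nn3)c3cc(CC=C(C)C)c(OC)cc3O2)cc1`, 100%
compound 2 `C#CCO/N=C1/C[C@@H](c2ccc(OC)cc2)Oc2cc(OC)c(CC=C(C)C)cc21`, 65%
compound 3 `COc1ccc([C@@H]2C/C(=N/OCc3cn(-c4ccc(O)cc4)nn3)c3cc(CC=C(C)C)c(OC)cc3O2)cc1`, 65%

In a functional assay on HCT-116 cells (Homo sapiens) for inhibition, read by sulforhodamine B assay, with a stated time of 48 h, tested at 50 uM (on this read-out lower numbers stand for less inhibition of growth and higher numbers for more inhibition of growth at the one concentration tested), compound 3 stands level with compound 2 at the digits shown, and the two together give the lowest numbers of the three; compound 1 sits well above, as the step of a number 35 percentage points lower from compound 1 to compound 3 (beyond the scatter) shows. The step of no change at the digits printed from compound 2 to compound 3 (within the scatter) shows that replacing the ethynyl group by the whole triazole with its hydroxyphenyl left the number unchanged.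

Compound 4 `COc1ccc([C@@H]2C/C(=N/OCc3cn(-c4ccc(NC(=O)c5ccccc5)cc4)nn3)c3cc(CC=C(C)C)c(OC)cc3O2)cc1` differs from compound 3 in one place: benzamido in place of hydroxy on an aromatic carbon. The step from compound 1 to compound 3 is the one that bears on this, since it also altered the group on that same phenyl ring and moved the number strongly; the step from compound 2 to compound 3 bears less on it. Within the data shown here, a benzamido group there has no measured counterpart, so the direction is open, and a modest rise is expected, a number 10 percentage points higher from compound 3 to compound 4 (within the scatter). Compound 4 is therefore estimated at 75%, within 40% to 100%.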

Compound 4, percent growth inhibition at one concentration: 8%
For compound 4 the middle estimate is 67 percentage points above the measured one; the whole stated range lies above it.
By their numbers in this assay, from the lowest: compound 4; then compounds 2 and 3 (each within the scatter of the next); then compound 1.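

In this assay, benzamido in place of hydroxy on this aromatic carbon, para to a large group, gives a number 57 percentage points lower from compound 3 to compound 4 (beyond the scatter) and shows that this position does not tolerate every group. Compound 3 and compound 2 sit level, but this added benzamido group, with its own six-membered aromatic ring, leaves little growth inhibition. No measurement available here explains the drop. On these data alone, whether the loss follows the added ring or the amide link stays open. An acetamido group or a plain amine at this position would help separate the two.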